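Swapping a Pyrrolidine Amide for a Cyclopropyl Amide

A few compounds are considered here, and "the series" means these few. Any claim that something is new, unique, unknown or untested is made for them only; others in the source may bear on it.

Three compounds sharing one core were tested in a functional assay on the whole organism with Rattus norvegicus as the target, at a dose of 20 mg/kg by the oral route; on this read-out higher numbers stand for more inhibition at the one dose given (going by the name of the read-out) and lower numbers for less inhibition. Compound 1 `NC(=O)/C=C1\CCc2c(F)cccc21`, which carries a plain primary amide, gives 34%. Compound 3 `O=C(/C=C1\CCc2c1ccc(F)c2F)NC1CC1`, with a cyclopropylamino amide and two fluorines on its aromatic ring, gives 27%. Compound 2 `O=C(/C=C1\CCc2ccc(F)cc21)N1CCCC1`, whose amide is closed into a pyrrolidin-1-yl ring, gives 18%, the lowest of the three numbers; its gap to compound 3 lies within the usual scatter, while its gap to compound 1 lies beyond it, so only compound 1 is clearly separated from it.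

Compound 4 `O=C(/C=C1\CCc2ccc(F)cc21)NC1CC1` has not been measured in this assay. It differs from compound 2 in one place: cyclopropylamino in place of pyrrolidin-1-yl on a carbonyl carbon. Among the measured compounds shown here, no measured pair shows this exact change, so its size is a guess. Since compound 3, also a cyclopropylamino amide, gives 27%, a modest rise is expected, likely no larger than the scatter, with a step of a number 7 percentage points higher from compound 2 to compound 4 (within the scatter). Compound 4 is therefore estimated at 25%, within 10% to 42%.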

Compound 4, a percentage reported as inhibition, in the whole organism at one dose (the size of the read-out at that dose, not a potency): 7%
Estimate against measurement, compound 4: 18 percentage points above, and the stated range ends above it.
By their numbers in this assay, from the lowest: compound 4; then compounds 2, 3 and 1 (each within the scatter of the next, the first and the last beyond it).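

Among the compounds shown here, with the rest of the molecule held fixed, cyclopropylamino in place of pyrrolidin-1-yl on a carbonyl carbon gives a number 11 percentage points lower from compound 2 to compound 4 (beyond the scatter) in this assay and so provides the first direct reading of this position. The number at this one dose therefore depends on which amine part the amide carries, and here the group that brings the amide hydrogen goes with the lower number, a finding that rests on this single pair. Nothing shown explains why the number falls with this change.

From the compounds shown here alone, it remains open where an open-chain group such as dimethylamino or a six-membered ring such as morpholin-4-yl would fall on the same carbonyl carbon, relative to compound 2 and compound 4. Going by these compounds, it is also open whether this swap would give a step of similar size with the fluorines placed differently on the shared core.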